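Fluoro in Place of Isobutyl: An Expected Gain

The source may report more compounds than this note shows. Statements on the series, on what has been measured and on what is new or still open speak of the compounds shown alone.

Three compounds share one core. Compound 1 `Cc1ccccc1NS(=O)(=O)c1ccc(N2CCNC2=O)cc1` carries a methyl group, compound 2 `CC(C)Cc1ccc(NS(=O)(=O)c2ccc(N3CCNC3=O)cc2)cc1` an isobutyl group, and compound 3 `CCCCCCOc1ccc(NS(=O)(=O)c2ccc(N3CCNC3=O)cc2)cc1` a hexyloxy group. In a functional assay on HT-29 cells (Homo sapiens) for antiproliferative activity, read by sulforhodamine B assay, with a stated time of 48 h (a lower number here means a stronger inhibitor, a higher number a weaker inhibitor), compound 1 gives 200 nM. Compound 2 reaches only a limit of the assay, > 1000 nM. Compound 3 likewise ends at a limit, > 1000 nM. The step from compound 2 to compound 3 is therefore a step that the two limits leave unreadable from compound 2 to compound 3, and the picture is shaped by the limit of > 1000 nM in this assay, at which 2 of the 3 values shown sit.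

Going by the values given here, compound 2 thus stands at a limit rather than at a number, and the one other value beside it is a limit as well. Compound 4 `O=C1NCCN1c1ccc(S(=O)(=O)Nc2ccc(F)cc2)cc1` differs from compound 2 by fluoro in place of isobutyl on an aromatic carbon. Among the compounds with values here, no measured step with a readable size bears on this change; the only step from compound 2 is unreadable. Within the data shown here, the one firm number in the set belongs to compound 1 with 200 nM, and compound 4 is expected to move back toward that region, so a step of an at least 2.5-fold lower number from compound 2 to compound 4 (0.39 log units; beyond the scatter) toward stronger inhibition is estimated. Compound 4 is expected to give 400 nM, within a range from 150 nM to 1200 nM.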

Compound 4, half-maximal inhibitory concentration: 370 nM
Estimate against measurement, compound 4: 1.1-fold (0.03 log units) above; the range from low to high includes it.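

In this assay, compound 4 puts a firm number on the aromatic carbon para to a large group, where isobutyl and hexyloxy gave only limits: fluoro brings an at least 2.7-fold lower number from compound 2 to compound 4 (0.43 log units; beyond the scatter) and an at least 2.7-fold lower number from compound 3 to compound 4 (0.43 log units; beyond the scatter). The result also shows that a firm number in this set is not confined to compound 1 with its methyl group: the change of the whole sulfonamide substituent, 4-fluorophenyl in place of 2-methylphenyl, is a 1.9-fold higher number from compound 1 to compound 4 (0.27 log units; within the scatter), so the two compounds cannot be told apart. The steps from compound 2 and compound 3 give only a lower bound on size, and their true size remains unknown: the limit of > 1000 nM in this assay, at which 2 of the 4 values shown sit.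

Whether the gain comes from removing the longer groups or from fluorine itself stays open, with fluoro the only group with a single heavy atom shown at this position. A chloro group, a methyl group or an amine on the same carbon would help separate these two readings, and a propyl chain would show how much carbon this position accepts before the number reaches the limit.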